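Replacing pyridin-2-yl with tert-butyl on the hydroxy-acyl side chain

This account rests on a few compounds, and the source may have more. Where it says the series, first, only, none or still open, it means among the compounds named here.

Measured compounds:
compound 1, `O=C(NCc1cc(Cl)ccc1-n1cnnn1)[C@@H]1C[C@@H]2C[C@@H]2N1C(=O)[C@H](O)Cc1ccccn1`, 1000 nM
compound 2, `O=C(NCc1cc(Cl)ccc1-n1cnnn1)[C@@H]1C[C@H]2C[C@H]2N1C(=O)[C@H](O)c1cccc(F)c1`, 1100 nM
compound 3, `O=C(NCc1cc(Cl)ccc1-n1cnnn1)[C@@H]1CC=NN1C(=O)[C@H](O)c1ccccc1`, 840 nM

Of the compounds shown here, three sharing a common core have been measured in a functional assay on a cell-free system (plasma, Homo sapiens), with a stated time of 3 min; on this read-out lower numbers stand for stronger inhibition and higher numbers for weaker inhibition. Compound 1 gives 1000 nM, compound 2 gives 1100 nM and compound 3 gives 840 nM. Compound 1 stands second highest of the three numbers, but both of its gaps, to compound 2 and to compound 3, lie within the scatter of repeated measurements, so no order among the three can be claimed.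

Compound 4, `CC(C)(C)C[C@@H](O)C(=O)N1[C@H](C(=O)NCc2cc(Cl)ccc2-n2cnnn2)C[C@@H]2C[C@@H]21`, has not yet been measured in this assay. It differs from compound 1 in one place: tert-butyl in place of pyridin-2-yl on a saturated chain carbon, two bonds along the chain from a carbonyl carbon and an oxygen on a saturated carbon. Going by the values given here, no pair of measured compounds shows this change, so its effect is unknown from the data at hand. The three measured compounds carry different side groups at this position and still give numbers within the scatter of each other, which suggests that the position tolerates change.

The author therefore expects the step of a 1.1-fold lower number from compound 1 to compound 4 (0.05 log units; within the scatter) to be no larger than the scatter. For compound 4 the estimate is 900 nM, with a range from 300 nM to 3000 nM.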

Compound 4, half-maximal inhibitory concentration: 570 nM
The estimate for compound 4 lay 1.6-fold (0.20 log units) above the measured number; low and high end bracket the measured number.
By their numbers in this assay, from the lowest: compounds 4, 3, 1 and 2 (each within the scatter of the next).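

In this assay, going by these compounds alone, the exchange of pyridin-2-yl for tert-butyl gives a 1.8-fold lower number from compound 1 to compound 4 (0.24 log units; within the scatter), and this is the first reading of a single change at this position, as the earlier compounds differ from one another in more than one place. Within the data shown here, it shows that the six-membered aromatic ring on this chain can give way to tert-butyl, a group with no ring and no hydrogen-bond acceptor, without a step beyond the scatter, which for this pair gives direct support to the tolerance that the earlier compounds only hinted at. No measurement shown here offers an explanation for this step.

Going by these compounds, whether an amine, a carboxylic acid or a longer chain at this place would also stay within the scatter remains open. So does whether tert-butyl would behave the same way on the cores of compound 2 and compound 3.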